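Furan to pyridine on the shared core: one-step note

A few compounds are considered here, and "the series" means these few. Any claim that something is new, unique, unknown or untested is made for them only; others in the source may bear on it.

Compound 1 `C/C(=N/Nc1nc(-c2ccc(C#N)cc2)cs1)c1ccccc1` and compound 2 `O=[N+]([O-])c1ccc(-c2csc(N/N=C\c3ccco3)n2)cc1` share a core. In an in vitro assay on BTI-TN-5B1-4 cells for inhibition of Amine oxidase [flavin-containing] B (Homo sapiens), read by Amplex Red, with a stated time of 15 min, tested at 100 uM (a higher number here means more inhibition at the concentration tested (going by the name of the read-out), a lower number less inhibition), compound 1 gives 40%, and compound 2 gives 40%, level with compound 1 within the scatter. Compound 3 `O=[N+]([O-])c1ccc(-c2csc(N/N=C\c3ccncc3)n2)cc1` differs from compound 2 in one place: pyridin-4-yl in place of furan-2-yl on a carbon with a double bond to nitrogen. Among the measured compounds shown here, no measured pair shows this exchange, so no step beyond the scatter is anticipated in either direction. Compound 3 is expected to give 37% in this assay, with a range from 12% to 60%. The expected step is a number 3 percentage points lower from compound 2 to compound 3 (within the scatter), within the scatter.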

Compound 3, a percentage reported as inhibition, at one concentration (the size of the read-out at that concentration, not a potency): "not active" (no number reported)
Compound 3 has no reported number here; the estimate stays without a comparison.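

Among the compounds shown here, compound 3 is reported as not active, without a number, so no step from compound 2 to compound 3 can be read. The compounds shown leave open what pyridin-4-yl in place of furan-2-yl does to inhibition. No supporting data bear on this result.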